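The source may hold more compounds than are shown below. What is called first, only, known or untested is meant among the compounds shown, and "the series" means these compounds.

Measured so far in a functional assay on HL-60 cells (Homo sapiens) for cytotoxicity, read by MTT assay, with a stated time of 24 h; on this read-out higher numbers stand for weaker inhibition and lower numbers for stronger inhibition:
- compound 1, `COC(=O)/C(=C\c1ccc(OC(=O)c2ccccc2)cc1)Sc1ccnc2cc(Cl)ccc12`, 30200 nM
- compound 2, `COC(=O)/C(=C\c1ccc(OC(=O)c2ccccc2OC)cc1)Sc1ccnc2cc(Cl)ccc12`, 44500 nM
- compound 3, `COC(=O)/C(=C\c1ccc(OC(=O)c2cccc(OC)c2OC)cc1)Sc1ccnc2cc(Cl)ccc12`, 13000 nM

Compound 3 gives the lowest number of the three: the steps of a 2.3-fold lower number from compound 1 to compound 3 (0.37 log units; beyond the scatter) and a 3.4-fold lower number from compound 2 to compound 3 (0.53 log units; beyond the scatter) both lie beyond the scatter, while a 1.5-fold higher number from compound 1 to compound 2 (0.17 log units; within the scatter) does not. Compound 4, `COC(=O)/C(=C\c1ccc(OC(=O)c2cc(OC)c(OC)c(OC)c2)cc1)Sc1ccnc2cc(Cl)ccc12`, has not been measured. It differs from compound 3 in one place: 3,4,5-trimethoxyphenyl in place of 2,3-dimethoxyphenyl on a carbonyl carbon. For the measured compounds named here, two measured steps bear on this change, both of which added a methoxy group to the ester-linked aromatic ring and both of which gave modestly lower numbers, as in a 2.3-fold lower number from compound 1 to compound 3 (0.37 log units; beyond the scatter) and a 3.4-fold lower number from compound 2 to compound 3 (0.53 log units; beyond the scatter). A further methoxy group might continue that trend, but its position also shifts, so the step is expected to be small, at most modest, toward a lower number. For compound 4 the estimated step is a 1.4-fold lower number from compound 3 to compound 4 (0.16 log units; within the scatter), giving an expected 9000 nM with a range from 3500 nM to 25000 nM.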

Compound 4, half-maximal inhibitory concentration: 4240 nM
Compound 4: the middle estimate sits 2.1-fold (0.33 log units) above what was measured; the measured number falls inside the stated range.
By their numbers in this assay, from the lowest: compound 4; then compound 3; then compounds 1 and 2 (each within the scatter of the next).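

In this assay, for the compounds shown here, the 3,4,5-trimethoxyphenyl group on this carbonyl carbon gives the lowest number so far, with every step to compound 4 beyond the scatter. Going by these compounds alone, the change from 2,3-dimethoxyphenyl gives a 3.1-fold lower number from compound 3 to compound 4 (0.49 log units; beyond the scatter), the change from phenyl gives a 7.1-fold lower number from compound 1 to compound 4 (0.85 log units; beyond the scatter), and the change from 2-methoxyphenyl gives a 10-fold lower number from compound 2 to compound 4 (1.02 log units; beyond the scatter), the only step here rated large. No available evidence explains these differences. Going by these compounds, whether the number of methoxy groups or their placement matters more remains open, as does how a hydroxy group or an amine on this ring would compare.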